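Phosphatase Inhibition Across Four Amide Variants of a Shared Core

The source may report more compounds than this note shows. Statements on the series, on what has been measured and on what is new or still open speak of the compounds shown alone.

Compound 1 `CCCNC(=O)COc1ccc2cc(C(O)(C(F)(F)F)C(F)(F)F)c(O)cc2c1`: in an assay on isolated protein for inhibition of receptor-type tyrosine-protein phosphatase C (Homo sapiens), read by spectrophotometry (on this read-out higher numbers stand for weaker inhibition and lower numbers for stronger inhibition), compound 1 gives > 20000 nM, a limit of the assay.
Compound 2 `O=C(COc1ccc2cc(C(O)(C(F)(F)F)C(F)(F)F)c(O)cc2c1)NCc1ccc(F)cc1`: in this assay compound 2 gives > 20000 nM, a limit of the assay.
Compound 3 `Cc1ccc(S(=O)(=O)NNC(=O)COc2ccc3cc(C(O)(C(F)(F)F)C(F)(F)F)c(O)cc3c2)cc1`: in this assay compound 3 gives 16100 nM.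

Among the compounds with values here, compound 3 carries the only number in the set; the other two values sit at the limit of > 20000 nM in this assay, at which 2 of the 3 values shown sit. Compound 4 `O=C(COc1ccc2cc(C(O)(C(F)(F)F)C(F)(F)F)c(O)cc2c1)Nc1ccccc1` differs from compound 3 by phenyl in place of ((4-methylphenyl)sulfonyl)amino on an amide-type nitrogen. Within the data shown here, two measured steps bear on this change, each arriving at compound 3 from a smaller amide substituent: an at least 1.2-fold lower number from compound 1 to compound 3 (0.09 log units; that floor lies within the scatter) and an at least 1.2-fold lower number from compound 2 to compound 3 (0.09 log units; that floor lies within the scatter). Both give only a floor that lies within the scatter, so the direction for the reverse move to a plain phenyl is open. The expected step from compound 3 is a 1.2-fold higher number from compound 3 to compound 4 (0.09 log units; within the scatter), and a limit rather than a number is plausible. The estimate for compound 4 is 20000 nM, with a range from 8000 nM to 50000 nM.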

Compound 4, half-maximal inhibitory concentration: > 20000 nM
Compound 4 was reported as a limit (the forecaster's own chance of this, stated with the estimate: 50%); the middle value sits exactly at the limit.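

In this assay, phenyl in place of ((4-methylphenyl)sulfonyl)amino on the amide-type nitrogen gives an at least 1.2-fold higher number from compound 3 to compound 4 (0.09 log units; that floor lies within the scatter), so this change adds an aryl amide to the series without showing a real difference from the sulfonyl hydrazide of compound 3. Compound 4 joins compound 1 and compound 2 at the limit: the limit of > 20000 nM in this assay, at which 3 of the 4 values shown sit. The steps reaching compound 4 from compound 1 and compound 2 cannot be read.

On these data alone, whether the ((4-methylphenyl)sulfonyl)amino group truly differs from phenyl stays open. Also open, as far as these compounds go, is how a carboxylic acid or an amine on this nitrogen's substituent would read.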